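The compounds below may be only part of what the source reports. "The series", "measured", "known", "first", "only" and "open" are said of these compounds alone.

Measured in a functional assay on MCF7 cells (Homo sapiens) for inhibition, read by CCK-8 assay, with a stated time of 48 h; a lower number here means a stronger inhibitor, a higher number a weaker inhibitor:
- Compound 1 `COc1cc(-c2ccnc3cc(-c4ccc(F)cc4)nn23)cc(OC)c1OC`: 1280 nM
- Compound 2 `COc1cc(-c2ccnc3cc(-c4cccc(C#N)c4)nn23)cc(OC)c1OC`: > 10000 nM, a limit of the assay and not a number
- Compound 3 `COc1cc(-c2ccnc3cc(-c4cn(C)c5ccccc45)nn23)cc(OC)c1OC`: 95 nM

Compound 3, at 95 nM, is the strongest inhibitor of the three in this assay. Compound 4 `COc1ccc(-c2cc3nccc(-c4cc(OC)c(OC)c(OC)c4)n3n2)cc1` has 4-methoxyphenyl in place of 1-methyl-1H-indol-3-yl on an aromatic carbon.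

The closest guide is a 13-fold lower number from compound 1 to compound 3 (1.13 log units; beyond the scatter), a large step in which the same 1-methyl-1H-indol-3-yl replaces 4-fluorophenyl. Read backwards, it suggests that giving up this group for a phenyl group will cost a large part of the activity. The step of an at least 100-fold lower number from compound 2 to compound 3 (2.02 log units; beyond the scatter) points the same way, but it rests on a limit. The step of an at least 7.8-fold higher number from compound 1 to compound 2 (0.89 log units; beyond the scatter) shows that the phenyl groups themselves can differ, so the outcome remains uncertain.

A large rise in the number is therefore expected, estimated as a 13-fold higher number from compound 3 to compound 4 (1.10 log units; beyond the scatter). The estimated value for compound 4 is 1200 nM, with an expected range from 350 nM to 4500 nM.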

Compound 4, half-maximal inhibitory concentration: 125 nM
For compound 4 the middle estimate is 9.6-fold (0.98 log units) above the measured one; the whole stated range lies above it.
By their numbers in this assay, from the lowest: compounds 3 and 4 (each within the scatter of the next); then compound 1. At a limit, above all of these: compound 2.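

A single six-membered aromatic ring can serve at this position as well as 1-methyl-1H-indol-3-yl, so the second ring of the indole is not needed for this level of activity: a 1.3-fold higher number from compound 3 to compound 4 (0.12 log units; within the scatter). What the phenyl ring carries matters greatly, as methoxy in place of fluoro gives a 10-fold lower number from compound 1 to compound 4 (1.01 log units; beyond the scatter), and 4-methoxyphenyl in place of 3-cyanophenyl gives an at least 80-fold lower number from compound 2 to compound 4 (1.90 log units; beyond the scatter). The figure for compound 2 in that last step is a limit of the assay and not a number: the limit of > 10000 nM in this assay, at which 1 of the 4 values shown sits.

Going by these compounds, only fluoro, nitrile and methoxy appear on the phenyl ring here, so it remains open how an amine, a carboxylic acid or a longer ether such as ethoxy would behave. On these data alone, all of this rests on one cell line, and how far it holds in other cells remains open.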